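Aryl Ether Replaces Ethyl on the Chain of Compound 1

The compounds below may be only part of what the source reports. "The series", "measured", "known", "first", "only" and "open" are said of these compounds alone.

Compound 1 `CCCOc1ccc(C(O)C2OC(=O)c3c(OC)cc(OC)cc32)cc1` gives the higher of the two numbers measured in a functional assay on RAW264.7 cells (Mus musculus) for inhibition, read by Griess assay, with stated times of 1 h and 24 h (a higher number here means a weaker inhibitor, a lower number a stronger inhibitor), at 9260 nM. Compound 2 `COc1cc(OC)c2c(c1)C(C(O)c1ccc(OCc3ccc(F)cc3)cc1)OC2=O`, which differs from it at one place, gives 760 nM in this assay, and that step, a 12-fold lower number from compound 1 to compound 2 (1.09 log units; beyond the scatter), is the only measured one that bears on the case. Compound 3 `COc1cc(OC)c2c(c1)C(C(O)c1ccc(OCc3ccc(OC(F)F)cc3)cc1)OC2=O` differs from compound 1 by 4-(difluoromethoxy)phenyl in place of ethyl on a saturated chain carbon bound to an oxygen on an aromatic ring. Since this change is of the same kind as the measured one, a step of similar size in the same direction is expected, a 10-fold lower number from compound 1 to compound 3 (1.01 log units; beyond the scatter). For compound 3 the estimate is 900 nM, with a range from 300 nM to 3000 nM.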

Compound 3, half-maximal inhibitory concentration: 5030 nM
The estimate for compound 3 lay 5.6-fold (0.75 log units) below the measured number; the whole stated range lies below it.
By their numbers in this assay, from the lowest: compound 2; then compounds 3 and 1 (each within the scatter of the next).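

In this assay, an aryl group on this saturated chain carbon does not by itself bring a lower number: 4-(difluoromethoxy)phenyl in place of ethyl gives a 1.8-fold lower number from compound 1 to compound 3 (0.27 log units; within the scatter). The substituent on the aromatic carbon of that aryl group matters, as difluoromethoxy in place of fluoro gives a 6.6-fold higher number from compound 2 to compound 3 (0.82 log units; beyond the scatter). Nothing available explains this difference. As far as these compounds go, it remains open how a chloro or methoxy group on that aromatic carbon would compare with fluoro and difluoromethoxy. Also open, from the compounds shown here alone, is whether an amine there would be tolerated.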